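Four carbamates on two cores, all at the assay limit

This account rests on a few compounds, and the source may have more. Where it says the series, first, only, none or still open, it means among the compounds named here.

Compound 1 `C#CCN1CCC(OC(=O)Nc2ccccc2)CC1` is a carbamate on one of two closely related cores. In an assay on BTI-TN-5B1-4 cells for inhibition of Amine oxidase [flavin-containing] A (Homo sapiens), read by fluorescence and Amplex Red, using microsomes, with a stated time of 15 min (on this read-out higher numbers stand for weaker inhibition and lower numbers for stronger inhibition), compound 1 reaches only the limit of the assay, > 100000 nM, and no number is reported. Compound 3 `C#CCN1CCC(OC(=O)Nc2ccc(C(C)C)cc2)CC1` arises from compound 1 by isopropyl in place of hydrogen on an aromatic carbon. In this assay compound 3 likewise sits at the limit, > 100000 nM. The step that the two limits leave unreadable from compound 1 to compound 3 therefore cannot be read, because both values stand at the limit of > 100000 nM in this assay, at which 3 of the 3 values shown sit.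

Compound 2 `C#CCN1CCCC(OC(=O)Nc2ccccc2)C1` has the same atoms as compound 1 joined differently; the difference between the two cores is not broken down here. In this assay compound 2 also gives only a limit, > 100000 nM, and not a number.

Compound 4 `C#CCN1CCCC(OC(=O)Nc2ccc(C(C)C)cc2)C1` has not yet been measured. It follows from compound 2 by isopropyl in place of hydrogen on an aromatic carbon, the same change that leads from compound 1 to compound 3. Nothing among the three measured compounds shows any readable movement on this read-out, and the pattern is claimed only for these compounds.

Resting on the limit that compound 2 shows and on the unreadable a step that the two limits leave unreadable from compound 1 to compound 3, the step is expected to be a step that the limit leaves unreadable from compound 2 to compound 4. Compound 4 is thus estimated at 150000 nM, between 50000 nM and 500000 nM, and most probably it too will be reported only as a limit.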

Compound 4, half-maximal inhibitory concentration: > 100000 nM
Compound 4 ended at the assay's limit (the forecaster's own chance of this, stated with the estimate: 85%); the middle value lies beyond the limit too.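

In this assay compound 4 gives > 100000 nM as a limit and not a number. No step can be read from compound 2 to compound 4, because both compounds stand at the same limit: the limit of > 100000 nM in this assay, at which 4 of the 4 values shown sit. The compounds shown leave open how strongly any of the four inhibits, and whether the isopropyl change or the difference between the two cores moves this read-out at all.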